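The source may hold more compounds than are shown below. What is called first, only, known or untested is meant among the compounds shown, and "the series" means these compounds.

Working notes on the series. Compound 1 `CC1=CC[C@H](C(C)(C)NC(=S)N/N=C/c2ccc(O)cc2)CC1` and compound 2 `CC1=CC[C@H](C(C)(C)NC(=S)N/N=C/c2ccccc2O)CC1` share the same core and differ only in the aryl group on the carbon with a double bond to nitrogen. In a functional assay on U-251 cells (Homo sapiens) for inhibition, read by sulforhodamine B assay, with a stated time of 48 h (on this read-out lower numbers stand for stronger inhibition of growth and higher numbers for weaker inhibition of growth), compound 1 reaches only the assay limit, > 100000 nM. In this assay, among the measured compounds shown here, compound 2 gives 10600 nM, the only actual number in the set. For the measured compounds named here, the single further value, that of compound 1, is a limit. The step of an at least 9.4-fold lower number from compound 1 to compound 2 (0.97 log units; beyond the scatter) rests on that limit at one end (the limit of > 100000 nM in this assay, at which 1 of the 2 values shown sits), so only its minimum size is known. Compound 3 `CC1=CC[C@H](C(C)(C)NC(=S)N/N=C/c2ccc(F)cc2)CC1` carries the change (4-fluorophenyl in place of 2-hydroxyphenyl on a carbon with a double bond to nitrogen). Going by the values given here, only the step from compound 1 to compound 2 bears on it: replacing 2-hydroxyphenyl with 4-hydroxyphenyl, the reverse of that step, costs at least a modest amount, and exchanging 2-hydroxyphenyl for 4-fluorophenyl, which removes the donor and acceptor counted above, is expected to cost at least as much. The step from compound 2 to compound 3 in this assay is expected to be a 4.7-fold higher number from compound 2 to compound 3 (0.67 log units; beyond the scatter), toward a higher number. Compound 3 is estimated at 50000 nM in this assay, within 12000 nM to 150000 nM, with a fair chance that only a limit is reported.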

Compound 3, concentration for total growth inhibition: > 100000 nM
Compound 3 ended at the assay's limit (the forecaster's own chance of this, stated with the estimate: 45%); middle value at least 2.0-fold (0.30 log units) away from the limit.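

On the carbon with a double bond to nitrogen, the exchange of 2-hydroxyphenyl for 4-fluorophenyl gives an at least 9.4-fold higher number from compound 2 to compound 3 (0.97 log units; beyond the scatter) in this assay, and only the minimum size of this step is known: the limit of > 100000 nM in this assay, at which 2 of the 3 values shown sit.

Compound 3 gives > 100000 nM, which is a limit and not a number. Compound 1 had shown such a loss only for 4-hydroxyphenyl, whereas compound 3 shows it for a group with 0 hydrogen-bond donors and 0 hydrogen-bond acceptors, so among the three aryl groups shown, 2-hydroxyphenyl alone gives a readable number in this assay.

The step between compound 1 and compound 3, fluoro in place of hydroxy on an aromatic carbon, cannot be read, so the two aryl groups at the limit cannot be ranked against each other. As far as these compounds go, it remains open whether the hydroxy group of 2-hydroxyphenyl is itself what matters, and whether a 2-methoxyphenyl or 2-aminophenyl group on this carbon would also give a number rather than a limit.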